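A few compounds are considered here, and "the series" means these few. Any claim that something is new, unique, unknown or untested is made for them only; others in the source may bear on it.

Measured compounds in a functional assay on PC-3 cells (Homo sapiens) for antiproliferative activity, read by MTT assay, with a stated time of 72 h; on this read-out higher numbers stand for weaker inhibition and lower numbers for stronger inhibition:
Compound 1 `O=C(CNc1cccc(Cl)c1)N[C@H]1CCOC1=O` gives > 64000 nM, a limit of the assay.
Compound 2 `O=C(CNc1ccccc1)N[C@H]1CCOC1=O` gives > 64000 nM, a limit of the assay.
Compound 3 `O=C(CNc1ccccc1Cl)N[C@H]1CCOC1=O` gives > 64000 nM, a limit of the assay.

Where compound 2 stands can be told only as a limit: no number exists for it, and the two further values shown are limits as well, all sitting at the limit of > 64000 nM in this assay, at which 3 of the 3 values shown sit. The two measured steps, a step that the two limits leave unreadable from compound 1 to compound 2 and a step that the two limits leave unreadable from compound 2 to compound 3, are therefore unreadable in size; whether adding or removing a chloro on the aromatic ring moves potency at all cannot be read from them.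

Compound 4 `O=C(CNc1ccc(Cl)cc1)N[C@H]1CCOC1=O` differs from compound 2 by chloro in place of hydrogen on an aromatic carbon. Within the data shown here, the two steps that bear on this change are exactly those chloro-for-hydrogen and hydrogen-for-chloro steps, both without a readable size, so no direction and no magnitude can be expected from them; the only guidance is that every chloro placement examined so far has left the value at the limit. The expected step that the limit leaves unreadable from compound 2 to compound 4 is thus one that would most likely remain hidden behind the same limit. Compound 4 is accordingly estimated to give 120000 nM in this assay, with a range from 30000 nM to 400000 nM, and is expected to be reported again only as a limit.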

Compound 4, half-maximal inhibitory concentration: > 64000 nM
Compound 4: only a limit was reported; the forecaster's own chance of this, stated with the estimate: 85%; the middle value lies beyond the limit too.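

No new step can be read between compound 2 and compound 4, which both stand at a limit of the assay: the limit of > 64000 nM in this assay, at which 4 of the 4 values shown sit.

The compounds shown leave open whether a chloro on the aromatic ring, at any of the placements examined, moves potency at all in this assay, and none of them gives a number for comparison.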